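The compounds below may be only part of what the source reports. "The series", "measured", "known", "first", "only" and "open" are said of these compounds alone.

The series shares one core and varies the group on the aromatic carbon between two ring nitrogen atoms. Compound 1 `CC(C)NC(=O)c1ccc(-c2cnn3c(NCC4CCOCC4)nc(OC4CCCC4)nc23)cc1` belongs to it, yet in a functional assay on OVCAR-3 cells (Homo sapiens) for antiproliferative activity (a lower number here means a stronger inhibitor of growth, a higher number a weaker inhibitor of growth), compound 1 gives "not determined" (no result reported), so no result was reported for it. Compound 2 `O=C(NC1CC1)c1ccc(-c2cnn3c(NCC4CCOCC4)nc(NC4CCCC4)nc23)cc1F` gives 1700 nM in this assay. Compound 3 `Cc1cc(-c2cnn3c(NCC4CCOCC4)nc(Nc4ccccc4)nc23)ccc1C(=O)NC1CC1` gives 1700 nM in this assay. Compound 3 therefore stands level with compound 2 at the digits shown, a gap within the scatter, and compound 1 offers no number against which to set it. For the measured compounds named here, no pair of measured compounds differs in a single place, so no measured step is available.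

Compound 4 `Cc1cc(-c2cnn3c(NCC4CCOCC4)nc(Oc4cccc(F)c4F)nc23)ccc1C(=O)NC1CC1` has not yet been measured. It differs from compound 3 by 2,3-difluorophenoxy in place of anilino on an aromatic carbon. Because compound 2 gives 1700 nM and compound 3 gives 1700 nM with different groups at that same carbon, the position appears to accept varied groups without a shift beyond the scatter, although only these two compounds support that view. The step of a 1.5-fold higher number from compound 3 to compound 4 (0.17 log units; within the scatter) is expected to be small, leaning toward a slightly higher concentration, and not clearly beyond the scatter. Compound 4 is estimated at 2500 nM, within a range from 800 nM to 8000 nM.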

Compound 4, concentration for 50% growth inhibition: 37 nM
Beside the measured number, compound 4's estimate is 68-fold (1.83 log units) above it, outside the stated range (below it).
By their numbers in this assay, from the lowest: compound 4; then compounds 2 and 3 (each within the scatter of the next).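

In this assay, for the compounds shown here, putting 2,3-difluorophenoxy in place of anilino on the aromatic carbon between two ring nitrogen atoms gives a 46-fold lower number from compound 3 to compound 4 (1.66 log units; beyond the scatter), the first step that can be read at this position. It shows that this position is not indifferent to its group: with the rest of compound 3 unchanged, one exchange there moves the number far beyond the scatter. Nothing available explains why the number moves so far.

The exchange changes the linking nitrogen to oxygen and adds two fluorine atoms in a single step, so the compounds shown do not separate these two changes; a plain phenoxy group or a 2,3-difluoroanilino group at the same carbon would be needed to tell them apart. On these data alone, it also stays open whether the 2,3-difluorophenoxy group has the same effect when the methyl group on the benzamide ring is replaced by fluorine or hydrogen, or when the cyclopropyl amide is replaced by an isopropyl amide.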